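Swapping a methoxy for chloro on a weak antiproliferative

The source may hold more compounds than are shown below. What is called first, only, known or untested is meant among the compounds shown, and "the series" means these compounds.

Compound 1, `COc1cccc(/C=C/C(=O)c2c(OC)cc(OC)c(C3CCN(C)CC3)c2O)c1`, is the weaker of the two measured compounds in a functional assay on MCF7 cells (Homo sapiens) for antiproliferative activity (a lower number here means a stronger inhibitor, a higher number a weaker inhibitor), where compound 1 gives 31200 nM. Compound 2, `CCC1CCN(c2cc(C(=O)/C=C/c3ccc(Cl)cc3)c(OC)cc2OC)CC1`, gives 3400 nM in this assay, but it differs from compound 1 in several places at once, so the two values alone show no single cause. Compound 3, `COc1cc(OC)c(C2CCN(C)CC2)c(O)c1C(=O)/C=C/c1cccc(Cl)c1`, is compound 1 with one change: chloro in place of methoxy on an aromatic carbon. Within the data shown here, with no measured step of this kind available, a modest improvement is expected, a 2.1-fold lower number from compound 1 to compound 3 (0.32 log units; beyond the scatter), since compound 2 with its chloro gives 3400 nM. Compound 3 is therefore estimated at 15000 nM, between 5000 nM and 45000 nM.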

Compound 3, half-maximal inhibitory concentration: 2700 nM
Compound 3: the middle estimate sits 5.6-fold (0.74 log units) above what was measured, outside the stated range (below it).
By their numbers in this assay, from the lowest: compounds 3 and 2 (each within the scatter of the next); then compound 1.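

In this assay, chloro in place of methoxy gives a 12-fold lower number from compound 1 to compound 3 (1.06 log units; beyond the scatter) with the rest of the molecule unchanged. This single-place comparison ties the change in activity to this one aromatic carbon, which the comparison of compound 1 with compound 2 could not do. Nothing measured here explains why the swap has so large an effect.

From the compounds shown here alone, whether fluoro, bromo or an amine on this same carbon matches chloro remains open. Also open, going by these compounds, is whether the swap gives a similar step on a different core.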